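The source may report more compounds than this note shows. Statements on the series, on what has been measured and on what is new or still open speak of the compounds shown alone.

In a functional assay on QG-56 cells (Homo sapiens) for cytotoxicity, read by MTT assay, with a stated time of 48 h (a lower number here means a stronger inhibitor, a higher number a weaker inhibitor), compound 2 (`COc1cc(/C=C/C(=O)C2=C(/C=C/c3ccc(O)c(OC)c3)NC(=S)NC2c2ccc(N(C)C)cc2)ccc1O`) gives 25000 nM and compound 1 (`COc1cc(/C=C/C(=O)C2=C(/C=C/c3ccc(O)c(OC)c3)NC(=S)NC2c2ccccc2O)ccc1O`) gives 50000 nM, so these two values lie within the usual scatter of each other. Compound 3 (`COc1cc(/C=C/C(=O)C2=C(/C=C/c3ccc(O)c(OC)c3)NC(=S)NC2c2ccccc2Cl)ccc1O`) has 2-chlorophenyl in place of 4-(dimethylamino)phenyl on a saturated ring carbon. Among the measured compounds shown here, only one measured step bears on this position, a 2.0-fold lower number from compound 1 to compound 2 (0.30 log units; within the scatter), and it stays within the scatter. Nothing beyond the scatter is therefore expected in this assay, and the estimated step is a 1.2-fold higher number from compound 2 to compound 3 (0.08 log units; within the scatter). Compound 3 is expected to give about 30000 nM, with an estimated range of 12000 nM to 60000 nM.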

Compound 3, half-maximal inhibitory concentration: 50000 nM
The estimate for compound 3 lay 1.7-fold (0.22 log units) below the measured number; measured number inside the range.
By their numbers in this assay, from the lowest: compounds 2, 1 and 3 (each within the scatter of the next).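

In this assay, 2-chlorophenyl in place of 4-(dimethylamino)phenyl on the saturated ring carbon gives a 2.0-fold higher number from compound 2 to compound 3 (0.30 log units; within the scatter), and chloro in place of hydroxy on the aromatic carbon gives no change at the digits printed from compound 1 to compound 3 (within the scatter). All three substituted phenyl groups at this position therefore lie within the scatter of one another, so neither change separates these compounds. No available evidence bears on this result. Going by these compounds, what remains open is whether replacing the phenyl ring with a non-aromatic group, such as a cyclohexyl ring or a carboxylic acid, would shift the number beyond the scatter.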